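This account rests on a few compounds, and the source may have more. Where it says the series, first, only, none or still open, it means among the compounds named here.

Measured so far:
- Compound 1 `Cc1ccc(-c2nc(=O)o[nH]2)c(-c2ccc([C@@H](C)N(CC3CC3)c3nc(C(=O)NS(=O)(=O)C4CC4)c(C(C)C)s3)cc2)c1` gives 5.2 h in an ADME assay on the whole organism (Macaca fascicularis); a higher number here means that the compound lasts longer, a lower number that the compound disappears faster.
- Compound 2 `Cc1ccc(-c2nc(=O)o[nH]2)c(-c2ccc([C@@H](C)N(CC3CC3)c3nc(C(=O)NS(=O)(=O)C4CC4)c(C4CC4)s3)cc2)c1` gives 6 h in this assay.

Compound 2 holds the higher of the two numbers, but its gap to compound 1 is small: a 1.2-fold higher number from compound 1 to compound 2 (0.06 log units; within the scatter). With that step within the scatter, the two compounds cannot be told apart on the number alone.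

Compound 3 `COCCc1sc(N(CC2CC2)[C@H](C)c2ccc(-c3cc(C)ccc3-c3nc(=O)o[nH]3)cc2)nc1C(=O)NS(=O)(=O)C1CC1` has not been measured yet. It differs from compound 2 at one place: 2-methoxyethyl in place of cyclopropyl on an aromatic carbon. Within the data shown here, the only measured step at this position of the shared core is the one from compound 1 to compound 2, where a branched three-carbon group gave way to a three-membered ring and the number barely moved. Among the measured compounds shown here, a flexible chain carrying an oxygen at this same place has no measured counterpart here, so the step from compound 1 to compound 2 is a weak guide. The expectation for compound 3 is therefore a step in this assay of about a 1.2-fold lower number from compound 2 to compound 3 (0.08 log units; within the scatter), with no firm direction. Compound 3 is estimated at 5 h, within a range of 2.5 h to 10 h.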

Compound 3, mean residence time: 4.2 h
The estimate for compound 3 lay 1.2-fold (0.08 log units) above the measured number, and the stated range covers the measured number.
By their numbers in this assay, from the lowest: compounds 3, 1 and 2 (each within the scatter of the next).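

In this assay, among these compounds, 2-methoxyethyl is the first group at this place, next to the ring sulfur, that has no ring or branch and carries an oxygen, yet the steps stay small: a 1.4-fold lower number from compound 2 to compound 3 (0.15 log units; within the scatter) and a 1.2-fold lower number from compound 1 to compound 3 (0.09 log units; within the scatter). What compound 1 and compound 2 showed for two carbon-only groups therefore now reaches a chain with a hydrogen-bond acceptor, and compound 1, compound 2 and compound 3 cannot be told apart on this number. Nothing available beyond the numbers themselves bears on this result.

As far as these compounds go, an amine, a carboxylic acid or a much longer chain at this same carbon could still move the number beyond the scatter, so the limits of what this position accepts remain open. The change from cyclopropyl to 2-methoxyethyl also removes the ring and adds the oxygen in a single step, and only a comparison with a plain butyl chain or a ring containing an oxygen would begin to separate those two changes.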